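This account rests on a few compounds, and the source may have more. Where it says the series, first, only, none or still open, it means among the compounds named here.

Of the compounds shown here, three of one shared core have been measured in an assay on CHO-K1 cells for displacement of a labelled ligand from prostaglandin E2 receptor EP1 subtype (Homo sapiens); on this read-out higher numbers stand for weaker inhibition and lower numbers for stronger inhibition. Compound 1 `Cc1cc(C(=O)NCc2ccccn2)nn1Cc1cc(Cl)ccc1OCc1ccccc1` gives 25.1 nM, compound 2 `Cc1cc(NC(=O)C2CCOCC2)nn1Cc1cc(Cl)ccc1OCc1ccccc1` gives 63.1 nM, and compound 3 `Cc1cc(NC(=O)c2ccccc2)nn1Cc1cc(Cl)ccc1OCc1ccccc1` gives 15.9 nM. Compound 3 carries the smallest of the three numbers, yet one of its gaps is a 1.6-fold lower number from compound 1 to compound 3 (0.20 log units; within the scatter), which is within the usual scatter, while the other is a 4.0-fold lower number from compound 2 to compound 3 (0.60 log units; beyond the scatter), a clear modest step.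

Compound 4 `Cc1cc(NC(=O)OCc2ccccn2)nn1Cc1cc(Cl)ccc1OCc1ccccc1` differs from compound 3 in one place: (pyridin-2-yl)methoxy in place of phenyl on a carbonyl carbon. Among the compounds with values here, two measured steps bear on this change. The step from compound 2 to compound 3 exchanged oxan-4-yl for phenyl on the same carbonyl carbon and gave a 4.0-fold lower number from compound 2 to compound 3 (0.60 log units; beyond the scatter), so leaving phenyl has a precedent for a modest weakening. The step from compound 1 to compound 3 shows that a (pyridin-2-yl)methyl-bearing group in this region sits within the scatter of benzamido, a 1.6-fold lower number from compound 1 to compound 3 (0.20 log units; within the scatter). Taken together, a modest rise in the number, or none beyond the scatter, is expected for this assay.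

Compound 4 is therefore estimated at 35 nM, with a likely range from 14 nM to 90 nM. That estimate corresponds to an expected step of a 2.2-fold higher number from compound 3 to compound 4 (0.34 log units; beyond the scatter).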

Compound 4, half-maximal inhibitory concentration: 79.4 nM
Beside the measured number, compound 4's estimate is 2.3-fold (0.36 log units) below it; measured number inside the range.
By their numbers in this assay, from the lowest: compounds 3 and 1 (each within the scatter of the next); then compounds 2 and 4 (each within the scatter of the next).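

On the carbonyl carbon that carries phenyl in compound 3, the larger (pyridin-2-yl)methoxy group gives weaker inhibition in this assay with a 5.0-fold higher number from compound 3 to compound 4 (0.70 log units; beyond the scatter) as its step, so this position does not accept every replacement for phenyl equally well. Within the data shown here, the same group and oxan-4-yl cannot be told apart, with a 1.3-fold higher number from compound 2 to compound 4 (0.10 log units; within the scatter) as their step, which leaves phenyl as the only one of the three groups on this carbonyl carbon whose number stands clear of the other two. A pyridine ring alone also does not settle the outcome: compound 1 and compound 4 both carry one, yet a 3.2-fold higher number from compound 1 to compound 4 (0.50 log units; beyond the scatter) separates them, so the way the ring is attached to the shared core makes a real difference here.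

Nothing measured here explains why these steps have the size they do. Still open, on these data alone, is whether the weakening follows the ring nitrogen or the added oxygen and carbon of the link, a question that benzyloxy on the same carbonyl carbon, or a pyridin-2-yl group placed directly on it, would help to separate.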